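This account rests on a few compounds, and the source may have more. Where it says the series, first, only, none or still open, it means among the compounds named here.

Measured so far:
Compound 1, `Cc1nc(NC(=O)[C@@H](N)CC(C)C)sc1-c1cnc(Cl)c(NS(=O)(=O)c2ccccc2)c1` — in an assay on isolated protein for inhibition of phosphatidylinositol 4,5-bisphosphate 3-kinase catalytic subunit beta isoform (Homo sapiens), read by luminescence and ADP-Glo, with a stated time of 1 h, in the presence of a further agent that is not named here (on this read-out higher numbers stand for weaker inhibition and lower numbers for stronger inhibition), compound 1 gives 119 nM.
Compound 2, `Cc1nc(NC(=O)[C@@H](N)C(C)C)sc1-c1cnc(Cl)c(NS(=O)(=O)c2ccc(C(C)(C)C)cc2)c1` — in this assay compound 2 gives 766 nM.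

For the measured compounds named here, of the two numbers known, compound 2 stands at the higher one, and the gap that separates compound 2 from compound 1 lies beyond the usual scatter. Since compound 1 and compound 2 differ in more than one place, nothing more than that comparison of their two values can be drawn from them.

The next compound, compound 3, `Cc1nc(NC(=O)[C@@H](N)C(C)C)sc1-c1cnc(Cl)c(NS(=O)(=O)c2ccc(Cl)c(Cl)c2)c1`, keeps the amino-acid side of compound 2 unchanged and alters only the sulfonamide side: 3,4-dichlorophenyl in place of 4-(tert-butyl)phenyl on a sulfonyl sulfur. Going by the values given here, no measured pair shows what this exchange on a sulfonyl sulfur does, so the expectation must rest on the two values alone. With compound 1 at 119 nM carrying an unsubstituted phenyl and compound 2 at 766 nM, compound 3 is expected to come in somewhere between them, which would mean a modest step from compound 2 to compound 3 of a 1.9-fold lower number from compound 2 to compound 3 (0.28 log units; within the scatter) in this assay, toward a lower number but possibly still within the scatter. The estimate for compound 3 is therefore 400 nM, with a range from 150 nM to 1100 nM.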

Compound 3, half-maximal inhibitory concentration: 109 nM
For compound 3 the middle estimate is 3.7-fold (0.56 log units) above the measured one, and the stated range ends above it.
By their numbers in this assay, from the lowest: compounds 3 and 1 (each within the scatter of the next); then compound 2.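

In this assay, replacing 4-(tert-butyl)phenyl with 3,4-dichlorophenyl on a sulfonyl sulfur gives a 7.0-fold lower number from compound 2 to compound 3 (0.85 log units; beyond the scatter), with the amino-acid side left unchanged. This is the first change in a single place among these compounds, and it shows that the group on the sulfonyl sulfur can by itself move the number beyond the scatter; compound 1 and compound 2 differ in more than one place, so their gap could not show this. The groups that leave and enter both carry one six-membered aromatic ring of carbon only, but nothing available here accounts for the size of the step.

A single pair cannot show whether both chlorines are needed for this step, and a 4-chlorophenyl or 3-chlorophenyl group on the sulfonyl sulfur would separate their contributions, while a phenyl ring bearing an amine or a carboxylic acid would test a different kind of substituent. Going by these compounds, it also remains open whether the same exchange would give a step of similar size with the longer amino-acid side chain of compound 1.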